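Compound 2 to compound 4: methyl in place of bromo

This account rests on a few compounds, and the source may have more. Where it says the series, first, only, none or still open, it means among the compounds named here.

Going by the values given here, in a functional assay on EC9706 cells (Homo sapiens) for cytotoxicity, read by MTT assay, with a stated time of 72 h (a lower number here means a stronger inhibitor, a higher number a weaker inhibitor), compound 2 (`O=C(CSC(=S)N[C@H]1CCOC1=O)Nc1ccc(Br)cc1`) gives 67400 nM, the only true number so far. Compound 1 (`O=C(CSC(=S)N[C@H]1CCOC1=O)Nc1ccc(Cl)cc1`) gives > 128000 nM, which is a limit. Compound 3 (`O=C(CSC(=S)N[C@H]1CCOC1=O)Nc1ccccc1Cl`) gives > 128000 nM, which is also a limit.

Compound 4 (`Cc1ccc(NC(=O)CSC(=S)N[C@H]2CCOC2=O)cc1`) is still unmeasured. It has methyl in place of bromo on an aromatic carbon, para to a large group (methyl in place of bromo on an aromatic carbon). Among the compounds with values here, no measured compound carries methyl, so the evidence is indirect. Within the data shown here, the closest precedent, with bromo in place of chloro, is an at least 1.8-fold lower number from compound 1 to compound 2 (0.27 log units; that floor lies within the scatter). With 2-chlorophenyl in place of 4-bromophenyl, the less direct precedent is an at least 1.8-fold higher number from compound 2 to compound 3 (0.27 log units; that floor lies within the scatter). The step that the two limits leave unreadable from compound 1 to compound 3 adds nothing further. Neither readable floor goes beyond the scatter, so no step beyond the scatter is expected in this assay, with any drift expected toward a higher number. The expected change is a 1.5-fold higher number from compound 2 to compound 4 (0.17 log units; within the scatter). For compound 4 the estimated value is 100000 nM, with an expected range of 50000 nM to 200000 nM.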

Compound 4, half-maximal inhibitory concentration: 93900 nM
Beside the measured number, compound 4's estimate is 1.1-fold (0.03 log units) above it; low and high end bracket the measured number.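

In this assay, 4-bromophenyl to 4-methylphenyl gives a 1.4-fold higher number from compound 2 to compound 4 (0.14 log units; within the scatter), so a true number at this position, on an aromatic carbon para to a large group, is no longer confined to bromo. Against the two chloro compounds, only floors can be read, with an at least 1.3-fold lower number from compound 3 to compound 4 (0.13 log units; that floor lies within the scatter) and an at least 1.3-fold lower number from compound 1 to compound 4 (0.13 log units; that floor lies within the scatter). Compound 1 and compound 3 each remain at a limit, not a number: the limit of > 128000 nM in this assay, at which 2 of the 4 values shown sit.

The compounds shown leave open whether any group at this position, such as an amine, a carboxylic acid or a methoxy group, moves the number beyond the scatter. No step shown here does so, and the true size of the steps from the two chloro compounds also stays open.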